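Swapping a Sulfonamide for an Amide on a Shared Core

The compounds below may be only part of what the source reports. "The series", "measured", "known", "first", "only" and "open" are said of these compounds alone.

Of the compounds shown here, two have been measured so far. Compound 1 `Oc1cccc2cc(-c3ccccc3)ccc12` carries only hydrogen at the position of interest, and in an assay for binding affinity to 17-beta-hydroxysteroid dehydrogenase type 2 (Homo sapiens), with a stated time of 20 min, tested at 1 uM (on this read-out lower numbers stand for less inhibition and higher numbers for more inhibition at the one concentration tested (going by the name of the read-out)), compound 1 gives 20%. Compound 2 `CS(=O)(=O)Nc1cccc(-c2ccc3c(O)cccc3c2)c1` adds a methanesulfonamido group on an aromatic carbon, and in this assay compound 2 gives 22%. Within the data shown here, the only measured step, a number 2 percentage points higher from compound 1 to compound 2 (within the scatter), shows that adding this group changed little. Compound 2 therefore stands with the higher of the two numbers, but its gap to compound 1 is within the scatter, so the two cannot be ordered.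

Compound 3 `CNC(=O)c1cccc(-c2ccc3c(O)cccc3c2)c1` has not yet been measured. It differs from compound 2 in one place: methylcarbamoyl in place of methanesulfonamido on an aromatic carbon. The group that enters keeps a hydrogen-bond donor and sits on the same aromatic carbon. Among the measured compounds shown here, the one step bearing on this change, from compound 1 to compound 2, was small, and no step shows what replacing one such group by another does. The expectation is therefore no shift beyond the scatter, so no change at the digits printed from compound 2 to compound 3 (within the scatter) is the estimated step. For compound 3 in this assay the estimate is 22%, with a likely range from 5% to 40%.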

Compound 3, a percentage reported as inhibition, at one concentration (the size of the read-out at that concentration, not a potency): 43%
Compound 3: middle estimate off by 21 percentage points, on the low side, outside the stated range (above it).
By their numbers in this assay, from the lowest: compounds 1 and 2 (each within the scatter of the next); then compound 3.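

This result shows that the position is not indifferent to what sits on it. In this assay, the methanesulfonamido group had left the number within the scatter of the unsubstituted compound, but exchanging it for methylcarbamoyl gives a number 21 percentage points higher from compound 2 to compound 3 (beyond the scatter), even though each group has 1 hydrogen-bond donor and sits on the same aromatic carbon. Measured against hydrogen, methylcarbamoyl gives a number 23 percentage points higher from compound 1 to compound 3 (beyond the scatter), so a group here can raise the inhibition seen at the one tested concentration, while the data offer no measurement that explains why these two groups differ.

The swap changes the heavy atoms and the hydrogen-bond acceptors together, so these compounds cannot show whether the carbonyl, the amide hydrogen or the methyl matters most for the higher number. As far as these compounds go, it also remains open how a carboxylic acid, an amine or a longer chain on the amide nitrogen would compare at this position, and whether the higher number at one concentration would carry over to a true measure of potency.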